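Phenethyloxy added to the biphenyl amide of compound 2

This account rests on a few compounds, and the source may have more. Where it says the series, first, only, none or still open, it means among the compounds named here.

Measured compounds:
compound 1 `O=C(O)c1cccc(NC(=O)c2cccc(OCc3ccccc3)c2)c1`: 1160 nM
compound 2 `O=C(O)c1cccc(NC(=O)c2cccc(-c3ccccc3)c2)c1`: 25 nM

In an assay on isolated protein for agonist activity at Bile acid receptor (Homo sapiens), read by TR-FRET, with a stated time of 3 h, in the absence of a further agent (on this read-out lower numbers stand for an effect already at smaller amounts and higher numbers for an effect only at larger amounts of compound), compound 1 gives 1160 nM and compound 2 gives 25 nM. Going by the values given here, compound 2 thus stands at the lowest of the two numbers, and the single step connecting them, a 46-fold lower number from compound 1 to compound 2 (1.67 log units; beyond the scatter), is large and beyond the scatter.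

Compound 3 `O=C(O)c1cccc(NC(=O)c2cccc(-c3cccc(OCCc4ccccc4)c3)c2)c1` is not yet measured. It differs from compound 2 by phenethyloxy in place of hydrogen on an aromatic carbon, the new group sitting on an aromatic carbon of a six-membered aromatic ring of carbon only, meta to a large group. Among the compounds with values here, no measured step describes an addition of this kind on the distal ring; the step from compound 1 to compound 2 concerns a different place and a different exchange, so it bears on compound 3 only by showing that this end of the molecule can move the number strongly. The direction of the present change cannot be read from the data. Compound 3 is therefore expected to lie near compound 2, with an estimated step of a 1.6-fold higher number from compound 2 to compound 3 (0.20 log units; within the scatter), and an estimated value of 40 nM, ranging from 8 nM to 250 nM.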

Compound 3, half-maximal effective concentration: 169 nM
Beside the measured number, compound 3's estimate is 4.2-fold (0.63 log units) below it, within the range that was stated.
By their numbers in this assay, from the lowest: compound 2; then compound 3; then compound 1.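

In this assay, phenethyloxy in place of hydrogen on an aromatic carbon, meta to a large group, gives a 6.8-fold higher number from compound 2 to compound 3 (0.83 log units; beyond the scatter), a modest step. The earlier step concerned a different place and a different exchange, whereas this one shows that the ring added in compound 2 can carry a substituent with a further six-membered aromatic ring of carbon only, at a measurable cost, while compound 3 still gives a value of 169 nM. Nothing available explains why the number rises with this addition.

Going by these compounds, with a single substituent at this place, it remains open how the number depends on the group's length or on its parts. A methoxy group, a hydroxyl group, an amine or a longer chain ending in phenyl on the same aromatic carbon would help separate the contributions of the ether oxygen, the two-carbon link and the terminal phenyl ring, and the same phenethyloxy group on another carbon of that ring would show how much its place matters.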